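Cyano to Trifluoromethyl on the Phenyl Ring

The source may report more compounds than this note shows. Statements on the series, on what has been measured and on what is new or still open speak of the compounds shown alone.

Of the compounds shown here, three share one core and have been tested in an ADME assay on Huh-5-2 cells (Homo sapiens) for cytotoxicity, read by WST assay, with a stated time of 3 days; on this read-out higher numbers stand for lower toxicity in this test and lower numbers for higher toxicity in this test. Compound 1 `O=c1c(O)c(-c2ccccc2)oc2cc(OCc3ccc(Cl)cc3)cc(O)c12` gives only a limit there, > 100000 nM, recorded as the limit of > 100000 nM in this assay, at which 1 of the 3 values shown sits. Compound 2 `Cc1ccc(COc2cc(O)c3c(=O)c(O)c(-c4ccccc4)oc3c2)cc1` gives 88000 nM in this assay. Compound 3 `N#Cc1ccc(-c2oc3cc(OCc4ccc(Cl)cc4)cc(O)c3c(=O)c2O)cc1` gives 67000 nM in this assay, and the gap between compound 3 and compound 2 lies within the scatter, so neither can be called more or less toxic. The two measured steps, an at least 1.1-fold lower number from compound 1 to compound 2 (0.05 log units; that floor lies within the scatter) and an at least 1.4-fold lower number from compound 1 to compound 3 (0.17 log units; that floor lies within the scatter), both stay within the scatter. Compound 4 `O=c1c(O)c(-c2ccc(C(F)(F)F)cc2)oc2cc(OCc3ccc(Cl)cc3)cc(O)c12` differs from compound 3 by trifluoromethyl in place of cyano on an aromatic carbon. Because an at least 1.4-fold lower number from compound 1 to compound 3 (0.17 log units; that floor lies within the scatter) stayed small when a group last entered this place, no movement beyond the scatter is expected in this assay. Compound 4 is therefore estimated at 75000 nM, between 35000 nM and 160000 nM, an expected step of a 1.1-fold higher number from compound 3 to compound 4 (0.05 log units; within the scatter).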

Compound 4, half-maximal cytotoxic concentration: 73000 nM
For compound 4 the middle estimate is 1.0-fold (0.01 log units) above the measured one; low and high end bracket the measured number.
By their numbers in this assay, from the lowest: compounds 3, 4 and 2 (each within the scatter of the next). At a limit, above all of these: compound 1.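

In this assay, trifluoromethyl in place of cyano at this place on the phenyl ring gives a 1.1-fold higher number from compound 3 to compound 4 (0.04 log units; within the scatter), so these two groups cannot be told apart here. Trifluoromethyl in place of hydrogen gives an at least 1.3-fold lower number from compound 1 to compound 4 (0.13 log units; that floor lies within the scatter), and this size is only a floor, set by a limit: the limit of > 100000 nM in this assay, at which 1 of the 4 values shown sits.

From the compounds shown here alone, whether an amine or a carboxylic acid at this place would shift the number beyond the scatter stays open. So does the true size of any step away from hydrogen, since the compound carrying hydrogen here has no exact number.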